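Restoring a ring hydroxy to compound 2

The source may report more compounds than this note shows. Statements on the series, on what has been measured and on what is new or still open speak of the compounds shown alone.

Going by the values given here, in a functional assay on HEL cells (Homo sapiens) for cytotoxicity (a higher number here means that more compound is tolerated, a lower number that less compound is tolerated), compound 2 `CCCCCCCCCCC#Cc1cc2cn([C@H]3C[C@H](O)[C@@H](CO)O3)c(=O)nc2o1` gives 36000 nM, the lower of the two numbers so far, and compound 1 `CCCCCCCCCCC#Cc1cc2cn([C@@H]3O[C@H](CO)[C@@H](O)[C@@H]3O)c(=O)nc2o1` gives 116000 nM. Compound 3 `CCCCCCCCCCC#Cc1cc2cn([C@@H]3O[C@H](CO)[C@@H](O)[C@H]3O)c(=O)nc2o1` differs from compound 2 by hydroxy in place of hydrogen on a saturated ring carbon. Among the compounds with values here, the one measured step bearing on this is the opposite change, which gave a 3.2-fold lower number from compound 1 to compound 2 (0.51 log units; beyond the scatter). Compound 3 is not the same structure as compound 1, so the reversal may be incomplete. A modest rise is therefore expected, a 2.2-fold higher number from compound 2 to compound 3 (0.35 log units; beyond the scatter). The estimated value for compound 3 is 80000 nM, with an expected range of 30000 nM to 200000 nM.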

Compound 3, half-maximal cytotoxic concentration: 44000 nM
The estimate for compound 3 lay 1.8-fold (0.26 log units) above the measured number; low and high end bracket the measured number.
By their numbers in this assay, from the lowest: compounds 2 and 3 (each within the scatter of the next); then compound 1.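

In this assay, hydroxy in place of hydrogen on this saturated ring carbon gave a 1.2-fold higher number from compound 2 to compound 3 (0.09 log units; within the scatter), so adding the group does not by itself move the number beyond the scatter. The configuration as drawn at this carbon does separate the two hydroxy compounds, with a 2.6-fold lower number from compound 1 to compound 3 (0.42 log units; beyond the scatter). That gap can be traced to a single difference: the fact that compounds 1 and 3 differ only in the configuration as drawn

Going by these compounds, whether an amine or a fluorine at this carbon would follow either hydroxy compound remains open. So does whether the configuration gap would persist with a shorter chain on the shared core.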